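The source may hold more compounds than are shown below. What is called first, only, known or untested is meant among the compounds shown, and "the series" means these compounds.

Measured compounds:
compound 1 `N/C(=N\NC(=S)N1CCCC1)c1ccc(F)cn1` with 82.3%
compound 2 `N/C(=N\NC(=S)N1CCSCC1)c1ccccn1` with 83.9%

In a functional assay on A-375 cells (Homo sapiens) for cytotoxicity, read by MTT assay, with a stated time of 72 h, tested at 10 uM (a lower number here means less inhibition of growth, a higher number more inhibition of growth at the concentration tested), compound 1 gives 82.3% and compound 2 gives 83.9%. Compound 2 carries the highest of the two numbers, yet compound 1 sits within the scatter of it, so the two values show no difference that can be relied on. Compound 3 `N/C(=N\NC(=S)N1CCSCC1)c1ccc(F)cn1` differs from compound 2 by fluoro in place of hydrogen on an aromatic carbon. No measured pair isolates this change, so its size is not shown by any step; what is shown is only that compound 1, which carries the same fluoro group on its ring, and compound 2, which does not, return values within the scatter of each other. From this, the step from compound 2 to compound 3 is expected to be none beyond the scatter, a number 0.9 percentage points lower from compound 2 to compound 3 (within the scatter). Compound 3 is therefore estimated at 83%, with a range from 70% to 92%.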

Compound 3, percent growth inhibition at one concentration: 70.9%
Estimate against measurement, compound 3: 12.1 percentage points above; the measured number falls inside the stated range.
By their numbers in this assay, from the lowest: compound 3; then compounds 1 and 2 (each within the scatter of the next).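

In this assay, with the thiomorpholin-4-yl group held fixed, fluoro in place of hydrogen on the aromatic carbon two atoms from the ring nitrogen gives a number 13 percentage points lower from compound 2 to compound 3 (beyond the scatter), so growth inhibition responds to this change at this position, which the earlier pair could not show because it differs in two places. With the fluoro group held fixed, thiomorpholin-4-yl in place of pyrrolidin-1-yl on the thiocarbonyl carbon gives a number 11.4 percentage points lower from compound 1 to compound 3 (beyond the scatter), so the effect of the fluoro group cannot be assumed to hold apart from the group on that carbon. Nothing available accounts for either step.

From the compounds shown here alone, whether the fluoro step keeps its size with pyrrolidin-1-yl on the thiocarbonyl carbon remains open. So does what chloro, methoxy or an amine would do on the same aromatic carbon.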